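The source may hold more compounds than are shown below. What is called first, only, known or untested is meant among the compounds shown, and "the series" means these compounds.

Measured in a functional assay on HT-29 cells (Homo sapiens) for inhibition, read by MTT assay, with a stated time of 48 h; a lower number here means a stronger inhibitor, a higher number a weaker inhibitor:
- Compound 1 `COc1ccc(-n2c(SC)nnc2-c2cc(OC)c(OC)c(OC)c2)cc1`: > 60000 nM
- Compound 2 `COc1cc(-c2nnc(S)n2-c2ccc(N(C)C)cc2)cc(OC)c1OC`: > 60000 nM

In this assay, compound 2 stands at > 60000 nM, a limit of the assay and not a number. Compound 1, which also bears a methyl on a sulfur, gives > 60000 nM, again a limit. Both compounds thus sit at the same limit: the limit of > 60000 nM in this assay, at which 2 of the 2 values shown sit.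

Compound 3 `COc1cc(-c2nnc(SC)n2-c2ccc(N(C)C)cc2)cc(OC)c1OC` has methyl in place of hydrogen on a sulfur. Among the compounds with values here, no measured step shows this change, so in this assay at most a modest shift towards stronger inhibition is expected, and the result may remain a limit. The expected at least 2.0-fold lower number from compound 2 to compound 3 (0.30 log units; that floor lies within the scatter) is therefore small. For compound 3 the estimated value is 30000 nM, expected within 3000 nM to 100000 nM.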

Compound 3, half-maximal inhibitory concentration: > 60000 nM
Compound 3 ended at the assay's limit (the forecaster's own chance of this, stated with the estimate: 55%); middle value at least 2.0-fold (0.30 log units) from the limit.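

Compound 3 joins compound 1 and compound 2 at the same limit, so neither step to compound 3 can be read: the limit of > 60000 nM in this assay, at which 3 of the 3 values shown sit.

The compounds shown leave open whether methyl in place of hydrogen on a sulfur, or dimethylamino in place of methoxy on an aromatic carbon, changes inhibition at all.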